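Compound 3 and a half-life still to come

The compounds below may be only part of what the source reports. "The series", "measured", "known", "first", "only" and "open" are said of these compounds alone.

Compounds measured so far in an ADME assay on microsomes from liver (Mus musculus, strain CD-1) for metabolic stability, read by LC-MS, with a stated time of 60 min, tested at 20 uM; a higher number here means that the compound lasts longer, a lower number that the compound disappears faster

Compound 1 `CC(Sc1nc2c(cnn2C)c(=O)n1-c1ccccc1)c1ccccn1` with 0.833 h

Compound 2 `Cn1ncc2c(=O)n(-c3ccccc3)c(SCc3cccc(F)c3)nc21` with 0.133 h

Of these two, compound 2 holds the lower number at 0.133 h and sits clearly under compound 1 in this assay. The next compound, compound 3 `CC(Sc1nc2c(cnn2C)c(=O)n1-c1ccccc1)c1ccccc1`, has not yet been measured. Its difference from compound 2 is 1-phenylethyl in place of 3-fluorobenzyl on a sulfur and so it carries 1-phenylethyl in place of 3-fluorobenzyl on a sulfur. For the measured compounds named here, only one measured step bears on this change. That step is a 6.3-fold lower number from compound 1 to compound 2 (0.80 log units; beyond the scatter) and it put 3-fluorobenzyl in place of 1-(pyridin-2-yl)ethyl on a sulfur. Compound 3 does not restore that group, so this step gives a likely direction but only a loose guide to size. A smaller upward change is expected, estimated as a 2.3-fold higher number from compound 2 to compound 3 (0.35 log units; beyond the scatter) in this assay. The half-life expected for compound 3 is 0.3 h with an estimated range from 0.12 h to 0.75 h.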

Compound 3, half-life: 0.133 h
Compound 3: the middle estimate sits 2.3-fold (0.35 log units) above what was measured, and the stated range covers the measured number.
By their numbers in this assay, from the lowest: compounds 2 and 3 (each within the scatter of the next); then compound 1.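

In this assay, 1-phenylethyl in place of 3-fluorobenzyl on the sulfur gives no change at the digits printed from compound 2 to compound 3 (within the scatter), so this exchange separates the two groups by nothing beyond the scatter. Phenyl in place of pyridin-2-yl, with the rest of the group kept, gives a 6.3-fold lower number from compound 1 to compound 3 (0.80 log units; beyond the scatter), which matches the size of the earlier drop, where the whole group had changed, and ties the full gap to this one ring exchange. Nothing measured here gives a reason for that gap.

The compounds shown leave open whether the higher number depends on pyridin-2-yl itself or would also appear with pyridin-3-yl or pyridin-4-yl on the same chain carbon. They also leave open whether pyridin-2-ylmethyl, lacking the extra chain carbon, would keep it.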